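Removing the Phenylsulfonyl from a Piperazine Core

The source may report more compounds than this note shows. Statements on the series, on what has been measured and on what is new or still open speak of the compounds shown alone.

Compound 3 `COc1cc2nc(C3CC3)nc(N3CCN(S(=O)(=O)c4ccccc4)CC3)c2cc1OC` sits at a limit in an in vitro assay on U2OS cells for agonist activity at neurotensin receptor type 2 (Homo sapiens), read by reporter gene assay and beta-arrestin recruitment; a lower number here means that less compound is needed, a higher number that more compound is needed for the effect: it gives > 80000 nM, which is a limit, not a number. Compound 1 `CCOc1ccccc1N1CCN(c2nc(C3CC3)nc3cc(OC)c(OC)cc23)CC1` likewise reaches only a limit of > 80000 nM in this assay. Compound 2 `COc1cc2nc(C3CC3)nc(N3CCN(c4ccccc4Cl)CC3)c2cc1OC` too shows only the limit > 80000 nM in this assay. Because the limit of > 80000 nM in this assay, at which 3 of the 3 values shown sit, holds for all three, the steps a step that the two limits leave unreadable from compound 1 to compound 3 and a step that the two limits leave unreadable from compound 2 to compound 3, both on the same ring nitrogen, and a step that the two limits leave unreadable from compound 1 to compound 2 cannot be sized. Compound 4 `COc1cc2nc(C3CC3)nc(N3CCNCC3)c2cc1OC` differs from compound 3 by hydrogen in place of phenylsulfonyl on an amine nitrogen in a ring. With no readable step to lean on, compound 4 is expected to remain near the limit, an estimated step that the limit leaves unreadable from compound 3 to compound 4. The estimate for compound 4 in this assay is 100000 nM, within 20000 nM to 400000 nM.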

Compound 4, half-maximal effective concentration: > 80000 nM
Compound 4 was reported as a limit (the forecaster's own chance of this, stated with the estimate: 85%); the middle value lies beyond the limit too.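

Compound 4 stays at a limit, so its steps from compound 1, compound 2 and compound 3 cannot be read: the limit of > 80000 nM in this assay, at which 4 of the 4 values shown sit. The compounds shown leave open whether any group on this ring nitrogen gives a measurable value in this assay.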